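This account rests on a few compounds, and the source may have more. Where it says the series, first, only, none or still open, it means among the compounds named here.

Measured so far in the series:

Compound 1, `COc1nc2ccccc2cc1/C=C/c1noc(-c2ccc(F)cc2)n1`, gives > 230000 nM in an ADME assay on HepG2 cells (Homo sapiens) for cytotoxicity, read by sulforhodamine B assay, with a stated time of 48 h (on this read-out lower numbers stand for higher toxicity in this test and higher numbers for lower toxicity in this test), a limit of the assay rather than a number.
Compound 2, `COc1nc2ccccc2cc1/C=C/c1noc(-c2ccccc2C)n1`, gives > 230000 nM in this assay, again a limit of the assay and not a number.

Compound 1 therefore stands only at a limit: it sits at the limit of > 230000 nM in this assay, at which 2 of the 2 values shown sit, and no number for it is known. Within the data shown here, the one measured step that changes the same position, a step that the two limits leave unreadable from compound 1 to compound 2, is left unreadable by the two limits, so its size cannot be told.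

Compound 3, `COc1nc2ccccc2cc1/C=C/c1noc(C)n1`, differs from compound 1 in one place: methyl in place of 4-fluorophenyl on an aromatic carbon. Among the measured compounds shown here, the only step that bears on this position gives no readable size, so the data supply no direction for the change to methyl.

Compound 3 is expected to show no readable step, a step that the limit leaves unreadable from compound 1 to compound 3, because the limit of > 230000 nM in this assay, at which 2 of the 2 values shown sit, is where every value shown sits. Compound 3 is therefore estimated at 300000 nM in this assay, within a range of 120000 nM to 1000000 nM, most likely reported as a limit again.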

Compound 3, half-maximal cytotoxic concentration: > 300000 nM
Compound 3 was reported as a limit (the forecaster's own chance of this, stated with the estimate: 80%); the middle value lies on the limit itself.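

In this assay, compound 1, compound 2 and compound 3 are all reported only as limits of the assay, so the steps among them cannot be read and the change to methyl shows neither size nor direction. The compounds shown leave open whether any group at this place gives a readable number in this assay.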